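From Diethylamide to Azetidinyl Amide: What Compound 4 May Show

The source may report more compounds than this note shows. Statements on the series, on what has been measured and on what is new or still open speak of the compounds shown alone.

In a functional assay on MIA PaCa-2 cells (Homo sapiens) for inhibition, read by MTT assay, with a stated time of 7 days (on this read-out lower numbers stand for stronger inhibition and higher numbers for weaker inhibition), compound 3 `CCN(CC)C(=O)[C@@H]1CCCN(S(=O)(=O)c2ccc(S(=O)(=O)N(CC)CC)cc2)C1` gives 6400 nM, the highest of the three numbers here, though compound 2 `CCN(CC)S(=O)(=O)c1ccc(S(=O)(=O)N2CCC[C@@H](C(=O)N(C)C(C)C)C2)cc1` with 6200 nM lies within the scatter of it, while compound 1 `CCN(CC)S(=O)(=O)c1ccc(S(=O)(=O)N2CCC[C@@H](C(=O)N[C@@H]3CCN(C(=O)OC(C)(C)C)C3)C2)cc1` with 200 nM sits far lower. Within the data shown here, the single measured step, a 1.0-fold higher number from compound 2 to compound 3 (0.01 log units; within the scatter), exchanges one tertiary amide for another and moves nothing beyond the scatter. Compound 4 `CCN1CC(NC(=O)[C@@H]2CCCN(S(=O)(=O)c3ccc(S(=O)(=O)N(CC)CC)cc3)C2)C1` is compound 3 with (1-ethylazetidin-3-yl)amino in place of diethylamino on a carbonyl carbon, so it gains an amide hydrogen as compound 1 carries one. Among the measured compounds shown here, no measured step covers that exchange; the values of compound 1 and compound 3 show a wide gap, but those two differ in more than one place. Compound 4 is therefore expected to land between them, a step of a 7.1-fold lower number from compound 3 to compound 4 (0.85 log units; beyond the scatter), estimated at 900 nM within 200 nM to 4000 nM.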

Compound 4, half-maximal inhibitory concentration: > 30000 nM
Compound 4 was reported as a limit; the forecaster's own chance of this, stated with the estimate: 3%; at least 33-fold (1.52 log units) between middle value and limit.
By their numbers in this assay, from the lowest: compound 1; then compounds 2 and 3 (each within the scatter of the next). At a limit, above all of these: compound 4.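

Compound 4 carries a limit of the assay, not a number: the limit of > 30000 nM in this assay, at which 1 of the 4 values shown sits. At this carbonyl carbon, (1-ethylazetidin-3-yl)amino does not follow compound 1, and the steps read an at least 4.6-fold higher number from compound 3 to compound 4 (0.67 log units; beyond the scatter) and an at least 4.8-fold higher number from compound 2 to compound 4 (0.68 log units; beyond the scatter). The amide hydrogen alone is thus not enough here: with 1-ethylazetidin-3-yl in place of 1-(tert-butoxycarbonyl)pyrrolidin-3-yl on that nitrogen, the record shows an at least 150-fold higher number from compound 1 to compound 4 (2.17 log units; beyond the scatter).

Still open, going by these compounds, is whether ring size or the group on the ring nitrogen decides this. A 1-(tert-butoxycarbonyl)azetidin-3-yl group on the amide nitrogen would separate those two.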